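A few compounds are considered here, and "the series" means these few. Any claim that something is new, unique, unknown or untested is made for them only; others in the source may bear on it.

Compound 1 `CN1CCCc2ccc(NC(=O)c3ccc(-c4ccccc4)cc3)cc21`: 7.5
Compound 2 `O=C(Nc1ccc2c(c1)NCCC2)c1ccc(-c2ccccc2)cc1`: 7.7
Compound 3 `COCC(=O)N1CCCc2ccc(NC(=O)c3ccc(-c4ccccc4)cc3)cc21`: 7.2

Of the compounds shown here, three built on one shared core have been read in a functional assay for antagonist activity at transient receptor potential cation channel subfamily V member 1 (Homo sapiens), read by FLIPR and calcium flux; on this read-out lower numbers stand for lower potency and higher numbers for higher potency (the scale is a negative logarithm). Compound 1 gives 7.5, the second highest of the three numbers. Its nearest neighbour is compound 2, where a number 0.20 log units higher from compound 1 to compound 2 (within the scatter). Its furthest is compound 3, where a number 0.30 log units lower from compound 1 to compound 3 (within the scatter). Between the other two, a number 0.50 log units lower from compound 2 to compound 3 (beyond the scatter).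

Every one of these measured steps concerns the substituent on the nitrogen of the saturated ring in the core. None of them alters the phenyl at the far end of the amide.

Compound 4 `CN1CCCc2ccc(NC(=O)c3ccc(-c4ccsc4)cc3)cc21` keeps the methyl on that nitrogen and differs from compound 1 in one place only: thiophen-3-yl in place of phenyl on an aromatic carbon. Among the compounds with values here, no measured step bears on this change, so compound 1 alone serves as the anchor, and the size of the step rests on no neighbouring pair. With nothing in the measured set pointing either way, the author expects compound 4 to stay close to compound 1, with a step of a number 0.20 log units lower from compound 1 to compound 4 (within the scatter) that would not exceed the scatter. For compound 4 the estimate is therefore 7.3, with a range from 6.7 to 7.9.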

Compound 4, negative logarithm of the antagonist equilibrium constant: 7.8
The estimate for compound 4 lay 0.50 log units below the measured number; the range from low to high includes it.
By their numbers in this assay, from the lowest: compounds 3, 1, 2 and 4 (each within the scatter of the next, the first and the last beyond it).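

Within the data shown here, until this point, only the substituent on the nitrogen of the saturated ring had been varied, so compound 4 gives the first reading at the other end of the molecule, on an aromatic carbon of a six-membered aromatic ring of carbon only, para to a large group. In this assay, thiophen-3-yl in place of phenyl gives a number 0.30 log units higher from compound 1 to compound 4 (within the scatter), so this read-out does not separate the two groups, even though the five-membered aromatic ring with 1 hetero atom brings 5 heavy atoms rather than 6, and 1 hydrogen-bond acceptor where phenyl has none. Among these compounds, nothing available gives a reason for this outcome, and the single pair cannot show how far the position would accept other groups.

From the compounds shown here alone, since thiophen-3-yl is paired only with the methyl on the nitrogen, it remains open whether it would read the same alongside hydrogen or (methoxymethyl)carbonyl at that nitrogen. Going by these compounds, it also remains open how thiophen-2-yl, furan-3-yl, pyridin-3-yl or a phenyl carrying a chlorine would read at the same aromatic carbon.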